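A Longer Hydroxyalkyl Chain on a Poorly Soluble Core

The source may report more compounds than this note shows. Statements on the series, on what has been measured and on what is new or still open speak of the compounds shown alone.

Compound 1 `OCCCCNc1nnc(-c2ccc(F)c(F)c2Nc2ccc(I)cc2F)o1`: < 3 ug/mL
Compound 2 `NCCNc1nnc(-c2ccc(F)c(F)c2Nc2ccc(I)cc2F)o1`: < 3 ug/mL

In a physicochemical assay for solubility, read by HPLC, in phosphate buffer, at pH 6.5 (a lower number here means a less soluble compound, a higher number a more soluble compound), compound 1 gives < 3 ug/mL, which is a limit of the assay and not a number. Compound 2 gives < 3 ug/mL, also a limit. The step that the two limits leave unreadable from compound 1 to compound 2 therefore cannot be sized; what the data show is the limit of < 3 ug/mL in this assay, at which 2 of the 2 values shown sit. Compound 3 `OCCCCCNc1nnc(-c2ccc(F)c(F)c2Nc2ccc(I)cc2F)o1` differs from compound 1 by hydroxymethyl in place of hydroxy on a saturated chain carbon, four bonds along the chain from a nitrogen on an aromatic ring. No measured step sizes this change, so the expected step that the limit leaves unreadable from compound 1 to compound 3 is small and the value is likely to remain a limit. The estimate for compound 3 is 2 ug/mL, ranging from 0.5 ug/mL to 4 ug/mL.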

Compound 3, solubility: < 3 ug/mL
Compound 3: a limit, no number; the forecaster's own chance of this, stated with the estimate: 80%; the middle value does not contradict the limit.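

No step among compound 1, compound 2 and compound 3 can be read, since all three give a limit and not a number: the limit of < 3 ug/mL in this assay, at which 3 of the 3 values shown sit.

On these data alone, what stays open is how far these three compounds truly differ, and whether any chain on the shared core gives a readable number.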